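The source may hold more compounds than are shown below. What is called first, only, known or untested is meant among the compounds shown, and "the series" means these compounds.

Measured in an in vitro ADME assay on microsomes from liver (Homo sapiens) for metabolic stability; on this read-out higher numbers stand for a longer-lived compound and lower numbers for a shorter-lived compound:
Compound 1 `COc1ccc(-c2cc(-c3ccc(S(N)(=O)=O)cc3)cnc2N)cn1` gives > 4.16 h, a limit of the assay.
Compound 2 `COc1ccc(-c2cc(-c3ccc4nccn4c3)cnc2N)cn1` gives 2.43 h.

Within the data shown here, compound 1 stands at the limit of > 4.16 h in this assay, at which 1 of the 2 values shown sits, so only a limit and no number is known for it, and no step between measured compounds is available. Compound 3 `COc1ccc(-c2cc(-c3ccc(C(=O)N(C)C)cc3)cnc2N)cn1` differs from compound 1 by dimethylcarbamoyl in place of sulfamoyl on an aromatic carbon, in words dimethylcarbamoyl in place of sulfamoyl on an aromatic carbon. Among the measured compounds shown here, with no measured step to lean on, the expected step from compound 1 to compound 3 in this assay is an at least 1.6-fold lower number from compound 1 to compound 3 (0.22 log units; that floor lies within the scatter), a modest shortening of half-life. Compound 3 is estimated at 2.5 h, with a range from 1 h to 5 h.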

Compound 3, half-life: 2.6 h
Compound 3: middle estimate off by 1.0-fold (0.02 log units), on the low side; the range from low to high includes it.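

In this assay, dimethylcarbamoyl in place of sulfamoyl on the aromatic carbon gives an at least 1.6-fold lower number from compound 1 to compound 3 (0.20 log units; that floor lies within the scatter). Only a floor can be read for this step, since compound 1 is a limit and not a number: the limit of > 4.16 h in this assay, at which 1 of the 3 values shown sits.

With a group carrying no hydrogen-bond donor at this position, compound 3 gives a measured number, 2.6 h.

The compounds shown do not separate the exchange of sulfonyl for carbonyl from the loss of the nitrogen hydrogens. A dimethylsulfamoyl or an unsubstituted carboxamide at this position would bear on that question.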